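The source may report more compounds than this note shows. Statements on the series, on what has been measured and on what is new or still open speak of the compounds shown alone.

Compound 1 `C/C=C(\C)C(=O)O[C@@H]1[C@]2(OC(=O)CCCC)C=C3C4=CC(=O)O[C@@H](c5ccoc5)[C@]4(C)CC[C@@H]3[C@@]3(C)[C@H](C[C@]1(C)[C@H]3[C@@H](O)C(=O)OC)O2`, compound 2 `C/C=C(\C)C(=O)O[C@@H]1[C@]2(OC(=O)C3CC3)C=C3C4=CC(=O)O[C@@H](c5ccoc5)[C@]4(C)CC[C@@H]3[C@@]3(C)[C@H](C[C@]1(C)[C@H]3[C@@H](O)C(=O)OC)O2` and compound 3 `C/C=C(\C)C(=O)O[C@@H]1[C@]2(OC(=O)C3CC3)C=C3C4=CC(=O)O[C@@H](c5ccoc5)[C@]4(C)CC[C@@H]3[C@@]3(C)[C@H](C[C@]1(C)[C@H]3[C@@H](OC(=O)C1CC1)C(=O)OC)O2` share one core and differ in their ester groups. In a functional assay on SK-OV-3 cells (Homo sapiens) for inhibition, read by MTT assay, with a stated time of 24 h (a lower number here means a stronger inhibitor, a higher number a weaker inhibitor), compound 1 gives 13700 nM, a measured number. Compound 2 gives > 100000 nM, which is a limit of the assay and not a number. Compound 3 gives > 100000 nM, which is also a limit. Compound 2 therefore stands at the limit of > 100000 nM in this assay, at which 2 of the 3 values shown sit.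

Compound 4 `C/C=C(\C)C(=O)O[C@@H]1[C@]2(OC(=O)CC)C=C3C4=CC(=O)O[C@@H](c5ccoc5)[C@]4(C)CC[C@@H]3[C@@]3(C)[C@H](C[C@]1(C)[C@H]3[C@@H](O)C(=O)OC)O2` changes compound 2 in one place: ethyl in place of cyclopropyl on a carbonyl carbon. In words, this is ethyl in place of cyclopropyl on a carbonyl carbon.

The most relevant measurement is the step of an at least 7.2-fold higher number from compound 1 to compound 2 (0.86 log units; beyond the scatter), which changed butyl to cyclopropyl at that same place. Compound 4 reverses the ring change, but its ethyl chain is not the butyl chain of compound 1, so only part of that step may return. The step that the two limits leave unreadable from compound 2 to compound 3 concerns a different place and gives no usable size.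

In this assay, a modest move toward a lower number is expected, though compound 4 could still stay at the limit. The expected step is an at least 2.8-fold lower number from compound 2 to compound 4 (0.45 log units; beyond the scatter). For compound 4, the estimated value is 35000 nM, with an expected range of 11000 nM to 100000 nM.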

Compound 4, half-maximal inhibitory concentration: > 100000 nM
Compound 4: a limit, no number; the forecaster's own chance of this, stated with the estimate: 35%; at least 2.8-fold (0.45 log units) between middle value and limit.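

In this assay compound 4 gives > 100000 nM, which is a limit of the assay and not a number. Replacing the butyl on the carbonyl carbon of compound 1 with ethyl gives an at least 7.2-fold higher number from compound 1 to compound 4 (0.86 log units; beyond the scatter), so a loss of this size at this position does not require the three-membered ring of compound 2, and a short open chain is enough to produce it. Steps between two limits cannot be read, so cyclopropyl and ethyl cannot be ranked against each other, and the series now gathers at a single ceiling: the limit of > 100000 nM in this assay, at which 3 of the 4 values shown sit.

Among the compounds shown, only the butyl chain of compound 1 gives a measured number at this position, so it remains open whether a propyl chain, which lies in length between ethyl and butyl, would also give one. On these data alone, it is equally open whether a longer chain such as hexyl would move the value of compound 1 toward a lower or a higher number.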